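A Flat Series Meets a Ring at the Same Place

The source may report more compounds than this note shows. Statements on the series, on what has been measured and on what is new or still open speak of the compounds shown alone.

Of the compounds shown here, three sharing one core have been measured in a functional assay on HepG2 cells (Homo sapiens) for inhibition, read by MTT assay, with a stated time of 3 days; a lower number here means a stronger inhibitor, a higher number a weaker inhibitor. The chloro compound 1 (`COc1cc(-c2nc3ccccc3s2)ccc1OCC(=O)NNC(=O)CCl`) gives 2890 nM. Compound 2 (`COc1cc(-c2nc3ccccc3s2)ccc1OCC(=O)NNC(=O)CN(C(C)=O)[C@@H](CS)C(=O)O`), which carries acetyl(1-carboxy-2-sulfanylethyl)amino, gives 3420 nM. Compound 3 (`COc1cc(-c2nc3ccccc3s2)ccc1OCC(=O)NNC(=O)CN[C@@H](CS(=O)(=O)O)C(=O)O`), which carries (1-carboxy-2-sulfoethyl)amino, gives 3690 nM, and it stands level with the other two, within the scatter of both.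

The next compound, compound 4 (`COc1cc(-c2nc3ccccc3s2)ccc1OCC(=O)NNC(=O)CN1CCC[C@H]1C(=O)O`), has 2-carboxypyrrolidin-1-yl in place of (1-carboxy-2-sulfoethyl)amino on a saturated chain carbon bound to a carbonyl carbon.

Among the compounds with values here, three measured steps bear on this change, as each alters that same place. Replacing chloro gave a 1.2-fold higher number from compound 1 to compound 2 (0.07 log units; within the scatter) with one group and a 1.3-fold higher number from compound 1 to compound 3 (0.11 log units; within the scatter) with the other, while exchanging those two groups gave a 1.1-fold higher number from compound 2 to compound 3 (0.03 log units; within the scatter). All three stay within the scatter, so this assay has so far shown little response to what stands at this place. Within the data shown here, no measured compound has a ring there, which leaves that part of the change untested. The expected result is a 1.2-fold lower number from compound 3 to compound 4 (0.06 log units; within the scatter), with no step beyond the scatter anticipated. For compound 4 the estimated value is 3200 nM, with an expected range from 1700 nM to 6000 nM.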

Compound 4, half-maximal inhibitory concentration: 2650 nM
Beside the measured number, compound 4's estimate is 1.2-fold (0.08 log units) above it; the range from low to high includes it.
By their numbers in this assay, from the lowest: compounds 4, 1, 2 and 3 (each within the scatter of the next).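

In this assay, the first ring at this place, the five-membered non-aromatic ring of 2-carboxypyrrolidin-1-yl, does not move the number out of the band set by the open-chain groups and chloro: the steps read a 1.4-fold lower number from compound 3 to compound 4 (0.14 log units; within the scatter) and a 1.3-fold lower number from compound 2 to compound 4 (0.11 log units; within the scatter) and also a 1.1-fold lower number from compound 1 to compound 4 (0.04 log units; within the scatter) with each of them printed as within the scatter. The part of the change that had stood untested therefore now has one answer, and for this one ring on a saturated chain carbon bound to a carbonyl carbon, the four compounds remain level, even though the change also removes the sulfur of compound 3. Nothing available accounts for this lack of response in the assay.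

Compounds 2, 3 and 4 all keep a carboxylic acid at this place and compound 1 has chloro instead, so the compounds shown leave open how a ring without that acid, such as piperidin-1-yl or morpholin-4-yl, or a plain dimethylamino group, would read. They also leave open whether the other stereoisomer of 2-carboxypyrrolidin-1-yl, or a six-membered ring bearing the same carboxylic acid, would stay as level.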